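The source may hold more compounds than are shown below. What is called first, only, known or untested is meant among the compounds shown, and "the series" means these compounds.

Compound 1 `Cc1ccc(Cn2c(=O)[nH]c3c(N)nc(C(F)(F)F)cc32)cn1`: < 8.5 mL.min-1.g-1 (a limit)
Compound 2 `Cc1ccc(Cn2c(=O)[nH]c3c(N)nc(C(F)(F)F)cc32)nn1`: < 11 mL.min-1.g-1 (a limit)
Compound 3 `Cc1cccc(Cn2c(=O)[nH]c3c(N)nc(C(F)(F)F)cc32)n1`: 27 mL.min-1.g-1

In an in vitro ADME assay on microsomes from liver (Rattus norvegicus) for metabolic stability (on this read-out lower numbers stand for slow clearance and higher numbers for fast clearance), compound 3 gives 27 mL.min-1.g-1. It is the only one of the three with a number, as the other two values are limits. Compound 4 `Cc1cc(Cn2c(=O)[nH]c3c(N)nc(C(F)(F)F)cc32)no1` differs from it as follows: 5-methyl-1,2-oxazol-3-yl in place of 6-methylpyridin-2-yl on a saturated chain carbon bound to an aromatic nitrogen. Among the compounds with values here, two measured steps bear on this change, an at least 3.1-fold higher number from compound 1 to compound 3 (0.50 log units; beyond the scatter) and an at least 2.4-fold higher number from compound 2 to compound 3 (0.38 log units; beyond the scatter), both ring changes at that same place. Neither involves 5-methyl-1,2-oxazol-3-yl, so only a modest fall is expected, namely a 2.1-fold lower number from compound 3 to compound 4 (0.32 log units; beyond the scatter). For compound 4 the estimated value is 13 mL.min-1.g-1, within an expected range of 6 mL.min-1.g-1 to 30 mL.min-1.g-1.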

Compound 4, intrinsic clearance in microsomes: < 9 mL.min-1.g-1
Compound 4: no number, only a limit (the forecaster's own chance of this, stated with the estimate: 35%); middle value at least 1.4-fold (0.15 log units) away from the limit.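

In this assay, a five-membered aromatic ring at this place, on a saturated chain carbon bound to an aromatic nitrogen, gives an at least 3.0-fold lower number from compound 3 to compound 4 (0.47 log units; beyond the scatter), so low values are not confined to six-membered rings. The value of compound 4 is a limit and not a number: the limit of < 9 mL.min-1.g-1 in this assay, at which 1 of the 4 values shown sits. The steps from compound 1 and from compound 2 to compound 4 cannot be read.

As far as these compounds go, how far the values of compound 1, compound 2 and compound 4 lie beneath their limits stays open. So does the outcome of an amine or a carboxylic acid in place of the methyl on the 5-methyl-1,2-oxazol-3-yl ring.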